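Adding a Second Chloro to a Weak Caco-2 Inhibitor

A few compounds are considered here, and "the series" means these few. Any claim that something is new, unique, unknown or untested is made for them only; others in the source may bear on it.

Of the compounds shown here, two sharing one core have been tested in a functional assay on Caco-2 cells (Homo sapiens) for inhibition, read by MTT assay, with a stated time of 48 h, tested at 10 uM; a higher number here means more inhibition of growth at the concentration tested, a lower number less inhibition of growth. Compound 1 `Cc1cc(=O)c2c(O)cc(OCc3ccc(Br)cc3)c([C@H]3CCN(C)C[C@H]3O)c2o1` gives 13% in this assay. Compound 2 `Cc1oc2c([C@H]3CCN(C)C[C@H]3O)c(O)cc(O)c2c(=O)c1C(O)c1cccc(Cl)c1` gives 4% in this assay, and the gap between compound 2 and compound 1 lies within the usual scatter of the measurement, so neither can be set above the other; both show only little inhibition of growth.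

Compound 3 `Cc1oc2c([C@H]3CCN(C)C[C@H]3O)c(O)cc(O)c2c(=O)c1C(O)c1cccc(Cl)c1Cl` is the next compound, not yet measured. It differs from compound 2 in one place: chloro in place of hydrogen on an aromatic carbon. Going by the values given here, no pair of measured compounds shows what such a change does here, so nothing in the data points to a step in either direction. The step of a number 4 percentage points higher from compound 2 to compound 3 (within the scatter) is therefore expected to stay within the scatter. Compound 3 is estimated to give 8% in this assay, expected between -5% and 25%.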

Compound 3, percent growth inhibition at one concentration: 3%
Compound 3: the middle estimate sits 5 percentage points above what was measured; the range from low to high includes it.
By their numbers in this assay, from the lowest: compounds 3, 2 and 1 (each within the scatter of the next).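

Placing a chloro on the aromatic carbon ortho to the existing chloro group, which turns 3-chlorophenyl into 2,3-dichlorophenyl, gives in this assay a step of a number 1 percentage points lower from compound 2 to compound 3 (within the scatter). Going by these compounds alone, this is the first measured step for this change, and it shows that the second chloro does not set compound 3 apart from compound 2, with both showing only little inhibition of growth. No measurement offers an explanation for this result.

Going by these compounds, whether a different group at this ring position, such as an amine or a carboxylic acid, would give a step beyond the scatter stays open. So does whether the same chloro would behave alike on another carbon of this ring, since a single step says nothing about the other positions.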